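Phenyl in place of pyridin-2-yl on the ring nitrogen

The compounds below may be only part of what the source reports. "The series", "measured", "known", "first", "only" and "open" are said of these compounds alone.

Compound 1 `Cc1ccc(N2CCN(Cn3nc(-c4ccc5c(c4)OCCO5)oc3=S)CC2)c(C)c1`, compound 2 `Fc1ccc(N2CCN(Cn3nc(-c4ccc5c(c4)OCCO5)oc3=S)CC2)cc1` and compound 3 `S=c1oc(-c2ccc3c(c2)OCCO3)nn1CN1CCN(c2ccccn2)CC1` share one core and differ only in the group on the amine nitrogen in a ring. In a functional assay on HeLa cells (Homo sapiens) for antiproliferative activity, read by MTT assay, with a stated time of 48 h (a higher number here means a weaker inhibitor, a lower number a stronger inhibitor), compound 1 gives > 50000 nM, a limit of the assay and not a number. Compound 2 likewise gives only a limit, > 50000 nM. Among the compounds with values here, compound 3 gives 25100 nM, the only number among the three. The steps of an at least 1.9-fold lower number from compound 1 to compound 3 (0.29 log units; that floor lies within the scatter) and an at least 1.9-fold lower number from compound 2 to compound 3 (0.29 log units; that floor lies within the scatter) have only floors, and those floors lie within the scatter, because of the limit of > 50000 nM in this assay, at which 2 of the 3 values shown sit. Compound 4 `S=c1oc(-c2ccc3c(c2)OCCO3)nn1CN1CCN(c2ccccc2)CC1` differs from compound 3 by phenyl in place of pyridin-2-yl on an amine nitrogen in a ring. Both measured steps toward pyridin-2-yl run the other way from this change, so a somewhat higher number, possibly a limit again, is expected for compound 4: 45000 nM, range 20000 nM to 100000 nM, a step of a 1.8-fold higher number from compound 3 to compound 4 (0.25 log units; within the scatter).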

Compound 4, half-maximal inhibitory concentration: > 50000 nM
Compound 4 gave a limit, no number (the forecaster's own chance of this, stated with the estimate: 45%); middle value at least 1.1-fold (0.04 log units) away from the limit.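

Within the data shown here, with phenyl in this assay, the unsubstituted ring joins 4-fluorophenyl and 2,4-dimethylphenyl at a limit, leaving pyridin-2-yl in compound 3 as the only group here with a number. Exchanging its hetero atom for carbon gives an at least 1.9-fold higher number from compound 3 to compound 4 (0.29 log units; that floor lies within the scatter), so no real loss can be claimed. The steps among compound 1, compound 2 and compound 4 cannot be read: the limit of > 50000 nM in this assay, at which 3 of the 4 values shown sit.

From the compounds shown here alone, whether pyridin-2-yl truly differs from phenyl remains open. Also open, going by these compounds, is whether pyrimidin-2-yl or a carboxylic acid on the phenyl would give a clearly lower number.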